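This account rests on a few compounds, and the source may have more. Where it says the series, first, only, none or still open, it means among the compounds named here.

Measured so far in a toxicity assay on THP-1 cells (Homo sapiens) for inhibition; on this read-out higher numbers stand for lower toxicity in this test and lower numbers for higher toxicity in this test:

Compound 1, `Cn1c(-c2cccc(Cl)c2)cnc1NC(=O)c1ccc(F)cc1`. In this assay compound 1 gives > 50000 nM, a limit of the assay and not a number.
Compound 2, `COc1cccc(-c2cnc(NC(=O)c3ccc(F)cc3)n2C)c1`. In this assay compound 2 gives > 100000 nM, again a limit.
Compound 3, `COc1ccc(-c2cnc(NC(=O)CCc3ccccc3)n2C)cc1`. In this assay compound 3 gives > 100000 nM, also a limit.

Compound 3 therefore stands at the upper limit of this assay, where two of the three values sit (the limit of > 100000 nM in this assay, at which 2 of the 3 values shown sit), with the third at a lower limit (the limit of > 50000 nM in this assay, at which 1 of the 3 values shown sits). Among the compounds with values here, the one step between measured compounds, a step that the two limits leave unreadable from compound 1 to compound 2, is left unreadable by the two limits and gives no scale for any change.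

Compound 4, `COc1ccc(-c2cnc(NC(=O)c3cccc(O)c3)n2C)cc1`, differs from compound 3 by 3-hydroxyphenyl in place of phenethyl on a carbonyl carbon. Within the data shown here, no measured step concerns a change on the carbonyl carbon, so nothing bears directly on it. Given that all three measured compounds sit at limits, the expectation for compound 4 is a value at or near the same limit in this assay, with a step of a number no higher from compound 3 to compound 4 (the limit leaves the size open) that is not expected to exceed the scatter. Compound 4 is estimated at 100000 nM, between 50000 nM and 200000 nM.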

Compound 4, half-maximal cytotoxic concentration: > 100000 nM
Compound 4: a limit, no number; the forecaster's own chance of this, stated with the estimate: 80%; the middle value lies on the limit itself.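

In this assay, within the data shown here, compound 3 and compound 4 both stand at a limit of the assay and not at a number, so no step between them can be read. As far as these compounds go, whether 3-hydroxyphenyl in place of phenethyl on a carbonyl carbon changes toxicity at all remains open.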